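The source may hold more compounds than are shown below. What is called first, only, known or untested is meant among the compounds shown, and "the series" means these compounds.

Compound 1, `CNc1ncc(C#Cc2ccc(C)cc2)cn1`: 704000 nM in an assay on HEK293 cells for positive allosteric modulation of metabotropic glutamate receptor 5 (Rattus norvegicus); on this read-out higher numbers stand for an effect only at larger amounts of compound and lower numbers for an effect already at smaller amounts.
Compound 2, `Cc1cccc(C#Cc2cnc(C(C)(C)C)nc2)c1`: "not active" (no number reported), with no number reported.

Going by the values given here, compound 1 provides the only number here; in this assay its value of 704000 nM means an effect only at very large amounts of compound. Compound 2 stands beside it without a number, so nothing can be ranked. Compound 3, `Cc1ccc(C#Cc2cnc(C(C)(C)C)nc2)cc1`, has not yet been measured. It differs from compound 1 in one place: tert-butyl in place of methylamino on an aromatic carbon. Among the compounds with values here, no pair of measured compounds shows this change on its own, so its size can only be guessed. Compound 2, which also carries tert-butyl, gave "not active" (no number reported), and compound 1 already sits at 704000 nM, the weak end of the read-out. From this the step of a 1.2-fold lower number from compound 1 to compound 3 (0.07 log units; within the scatter) is expected to be small or to lead to no measurable effect at all. Compound 3 is therefore estimated at 600000 nM, between 150000 nM and 2000000 nM, with a considerable chance that only a limit is reported.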

Compound 3, half-maximal effective concentration: "not active" (no number reported)
Compound 3 has no reported number here, and the estimate cannot be compared.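

Compound 3, like compound 2, gave no number, so no step from compound 1 to compound 3 can be read, and nothing measured here offers an explanation. As far as these compounds go, whether tert-butyl in place of methylamino changes the effect at all remains open.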